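The source may hold more compounds than are shown below. What is called first, only, known or untested is meant among the compounds shown, and "the series" means these compounds.

Measured in a functional assay on A549 cells (Homo sapiens) for inhibition, read by MTT assay, with a stated time of 72 h; a higher number here means a weaker inhibitor of growth, a lower number a stronger inhibitor of growth:
- compound 1 `CC1(C)CCC[C@]2(C)[C@@H](C=O)C(C=O)=CC[C@@H]12`: 90000 nM
- compound 2 `CC1(C)CCC[C@]2(C)[C@@H](C=O)C(/C=C/C(=O)OCc3ccccc3)=CC[C@@H]12`: 28000 nM

Compound 2 has the lower of the two numbers, and its gap to compound 1 lies beyond the usual scatter. Compound 3 `CC(=O)/C=C/C1=CC[C@H]2C(C)(C)CCC[C@]2(C)[C@H]1C=O` has not yet been measured. It differs from compound 2 by methyl in place of benzyloxy on a carbonyl carbon. Within the data shown here, no measured pair shows this change, so the expectation is uncertain. In this assay, a small step towards a higher number is expected, not beyond the scatter. This estimate corresponds to a 1.4-fold higher number from compound 2 to compound 3 (0.15 log units; within the scatter). The estimated value for compound 3 is 40000 nM, with an expected range of 15000 nM to 100000 nM.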

Compound 3, concentration for 50% growth inhibition: 24000 nM
For compound 3 the middle estimate is 1.7-fold (0.22 log units) above the measured one; the measured number falls inside the stated range.
By their numbers in this assay, from the lowest: compounds 3 and 2 (each within the scatter of the next); then compound 1.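

In this assay methyl in place of benzyloxy on a carbonyl carbon gives a 1.2-fold lower number from compound 2 to compound 3 (0.07 log units; within the scatter) and so the aromatic ring of benzyloxy can be lost with no shift beyond the scatter. The modest step of a 3.8-fold lower number from compound 1 to compound 3 (0.57 log units; beyond the scatter) comes with 2-acetylethenyl in place of formyl on a double-bonded ring carbon. No measurement shown explains either result.

On these data alone, what remains open is how an amine or a longer chain in place of methyl on that carbonyl carbon would read in this assay and whether any such group would reach a clearly lower number.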